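The source may hold more compounds than are shown below. What is called first, only, known or untested is meant among the compounds shown, and "the series" means these compounds.

The account covers two compounds measured in an ADME assay on Vero 76 cells (Chlorocebus sabaeus) for cytotoxicity, read by neutral red uptake (on this read-out lower numbers stand for higher toxicity in this test and higher numbers for lower toxicity in this test), and one compound still to be tested there. Compound 1, `CC(C)C(Nc1nc(Cl)nc2c1ncn2[C@H]1[C@H](O)[C@H](O)[C@]2(CO)C[C@H]12)C(C)C`, gives in this assay a result of > 100000 nM, which is a limit of the assay rather than a number. Compound 2, `NCCNC(=O)[C@@]12C[C@@H]1[C@@H](n1cnc3c(NC(C4CC4)C4CC4)nc(Cl)nc31)[C@H](O)[C@@H]2O`, gives in this assay 50000 nM. Among the compounds with values here, this is the only actual number in the set, since the remaining value sits at the limit of > 100000 nM in this assay, at which 1 of the 2 values shown sits, so compound 2 stands as the single measured point from which anything can be reasoned. Compound 3, `NCCCNC(=O)[C@@]12C[C@@H]1[C@@H](n1cnc3c(NC(C4CC4)C4CC4)nc(Cl)nc31)[C@H](O)[C@@H]2O`, is the unmeasured partner of compound 2. It differs from compound 2 by aminomethyl in place of amino on a saturated chain carbon, two bonds along the chain from an amide-type nitrogen. Within the data shown here, no step between two measured compounds is available to calibrate this change, and a lengthening of the chain of this kind gives no ground to expect a shift in cytotoxicity. The step expected from compound 2 to compound 3 is therefore no change at the digits printed from compound 2 to compound 3 (within the scatter), nothing beyond the scatter. Compound 3 is expected to give in this assay about 50000 nM, within a range from 25000 nM to 100000 nM.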

Compound 3, half-maximal cytotoxic concentration: 50000 nM
Beside the measured number, compound 3's estimate shows no gap at the digits printed; low and high end bracket the measured number.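

In this assay, within the data shown here, the change of aminomethyl in place of amino on a saturated chain carbon, two bonds along the chain from an amide-type nitrogen, gives no change at the digits printed from compound 2 to compound 3 (within the scatter), and this is the first step between two measured compounds in the set. Compound 2 alone could not show how the read-out responds to any single change, whereas this pair shows that, for these two compounds, going from (2-aminoethyl)amino to (3-aminopropyl)amino leaves the half-maximal cytotoxic concentration within the usual scatter. Nothing measured here speaks to why the read-out responds in this way.

The compounds shown leave open whether the same holds for a still longer chain, such as 4-aminobutyl, or for a chain of the same length carrying a carboxylic acid or a hydroxyl group in place of the amino group. They also leave open whether a dimethylamino group at the end of the chain would read the same in this assay, since this single step covers only one lengthening with the primary amine kept.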